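This account rests on a few compounds, and the source may have more. Where it says the series, first, only, none or still open, it means among the compounds named here.

In a functional assay on A549 cells (Homo sapiens) for inhibition, read by sulforhodamine B assay (on this read-out higher numbers stand for weaker inhibition of growth and lower numbers for stronger inhibition of growth), two compounds sharing one core have been measured so far. Compound 1 `FC(F)(F)Oc1ccc(-c2ccc(-c3ccc(-c4nc5ccccc5[nH]4)cc3)cc2)cc1`, with trifluoromethyl on an oxygen on an aromatic ring, gives 38000 nM. Compound 2 `Oc1ccc(-c2ccc(-c3ccc(-c4nc5ccccc5[nH]4)cc3)cc2)cc1`, with hydrogen at that place, gives 33100 nM. The two numbers are effectively level, since the measured change is a 1.1-fold lower number from compound 1 to compound 2 (0.06 log units; within the scatter). Compound 2 therefore has the lower number only nominally.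

Compound 3 `COc1ccc(-c2ccc(-c3ccc(-c4nc5ccccc5[nH]4)cc3)cc2)cc1` follows from compound 2 by one change: methyl in place of hydrogen on an oxygen on an aromatic ring. Methyl takes the place of hydrogen on the oxygen, turning hydroxy into methoxy. Going by the values given here, only one measured step bears on this place, and it is small: a 1.1-fold lower number from compound 1 to compound 2 (0.06 log units; within the scatter). With so little movement seen there, no step beyond the scatter is expected, in either direction, though a single step is thin evidence. The expected change is a 1.1-fold higher number from compound 2 to compound 3 (0.02 log units; within the scatter). Compound 3 is estimated at 35000 nM, with an expected range from 15000 nM to 75000 nM.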

Compound 3, concentration for 50% growth inhibition: 38100 nM
Compound 3: middle estimate off by 1.1-fold (0.04 log units), on the low side; measured number inside the range.
By their numbers in this assay, from the lowest: compounds 2, 1 and 3 (each within the scatter of the next).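

In this assay, methyl on the oxygen brings no readable shift from hydroxy (a 1.2-fold higher number from compound 2 to compound 3 (0.06 log units; within the scatter)), and methyl and trifluoromethyl also cannot be told apart (a 1.0-fold higher number from compound 1 to compound 3 (0.00 log units; within the scatter)). Hydrogen, methyl and trifluoromethyl at this place therefore all give numbers within the scatter of one another, so the flat result of the first step now holds across three groups on this oxygen rather than resting on a single pair. Nothing available here accounts for this flatness.

The compounds shown leave open whether a longer chain on this oxygen, or an amine or a carboxylic acid in place of the hydroxy, would move the number beyond the scatter. They also leave open whether changes elsewhere on the shared core would move it further than any group at this place has.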